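A few compounds are considered here, and "the series" means these few. Any claim that something is new, unique, unknown or untested is made for them only; others in the source may bear on it.

Measured compounds in a functional assay on DU-145 cells (Homo sapiens) for cytotoxicity, read by MTT assay, with a stated time of 72 h; a higher number here means a weaker inhibitor, a lower number a stronger inhibitor:
- compound 1, `COc1ccc(C(=O)c2cc(OC)c(OC)c(OC)c2)cc1NC(=O)/C=C/c1cc(OC)c(OC)c(OC)c1`, 6300 nM
- compound 2, `COc1ccc(C(=O)c2cc(OC)c(OC)c(OC)c2)cc1NC(=O)/C=C/c1ccc(F)c(F)c1`, 10200 nM
- compound 3, `COc1cc(C(=O)c2cc(OC)c(OC)c(OC)c2)cc(NC(=O)/C=C/c2cc(OC)c(OC)c(OC)c2)c1OC`, 6600 nM

All three numbers sit within the scatter of one another, so no order among them can be read: compound 3 is separated from compound 1 by a gap that is negligible and from compound 2 by one that is still within the scatter. The step from compound 1 to compound 3, a methoxy in place of hydrogen on an aromatic carbon, gave a 1.0-fold higher number from compound 1 to compound 3 (0.02 log units; within the scatter), and the exchange of the cinnamoyl aryl from compound 1 to compound 2 gave a 1.6-fold higher number from compound 1 to compound 2 (0.21 log units; within the scatter).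

Compound 4, `COc1cccc(/C=C/C(=O)Nc2cc(C(=O)c3cc(OC)c(OC)c(OC)c3)cc(OC)c2OC)c1`, has not yet been measured in this assay. It differs from compound 3 in one place: 3-methoxyphenyl in place of 3,4,5-trimethoxyphenyl on a double-bonded chain carbon bound to a double-bonded chain carbon. For the measured compounds named here, the step that bears on it is the one from compound 1 to compound 2, where the same 3,4,5-trimethoxyphenyl was exchanged at the same place for another aryl and the number moved only within the scatter. A change of similar size is therefore expected for compound 4, if anything toward a slightly higher number, as a 1.4-fold higher number from compound 3 to compound 4 (0.13 log units; within the scatter). Compound 4 is estimated at 9000 nM, with a range from 4000 nM to 20000 nM.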

Compound 4, half-maximal inhibitory concentration: 12500 nM
Beside the measured number, compound 4's estimate is 1.4-fold (0.14 log units) below it; low and high end bracket the measured number.
By their numbers in this assay, from the lowest: compounds 1, 3, 2 and 4 (each within the scatter of the next).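

In this assay, the exchange of 3,4,5-trimethoxyphenyl for 3-methoxyphenyl on a double-bonded chain carbon bound to a double-bonded chain carbon gave a 1.9-fold higher number from compound 3 to compound 4 (0.28 log units; within the scatter). This extends the earlier reading in two ways: a second replacing aryl has now been tested at this place, on the core of compound 3 rather than that of compound 1, and the group entering has fewer heavy atoms and fewer hydrogen-bond acceptors than the group leaving, yet the step still does not clear the scatter, as was also the case for a 1.6-fold higher number from compound 1 to compound 2 (0.21 log units; within the scatter). No measurement is available that could explain this tolerance at the position, and none separates the two methoxy groups that are lost.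

Going by these compounds, whether any group at this place can move the number beyond the scatter remains open, since all four compounds carry a substituted phenyl there and none has an amine, a carboxylic acid or a pyridine ring in its stead. Also open, on these data alone, is whether 3-methoxyphenyl on the core of compound 1 would behave as it does on the core of compound 3.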